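The compounds below may be only part of what the source reports. "The series", "measured", "known", "first", "only" and "open" are said of these compounds alone.

Measured so far:
- compound 1 `COc1ccccc1-c1cccc(S(=O)(=O)N2CCC(N3CCC(C)CC3)CC2)c1`: 21 nM
- compound 2 `CC1CCN(C2CCN(S(=O)(=O)c3cn(C)cn3)CC2)CC1`: a limit only
- compound 3 `Cc1cc(C)c(S(=O)(=O)N2CCN(C3CN4CCC3CC4)CC2)c(C)c1`: 84 nM

In a functional assay on DLD-1 cells (Homo sapiens) for antiproliferative activity, read by CellTiter-Glo, with a stated time of 72 h (a lower number here means a stronger inhibitor, a higher number a weaker inhibitor), compound 1 gives 21 nM, the lowest of the two numbers shown. Compound 3 gives 84 nM, a gap beyond the scatter. Compound 2 gives > 5000 nM, which is a limit of the assay rather than a number, and it sits at the limit of > 5000 nM in this assay, at which 1 of the 3 values shown sits.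

Compound 4 `CC1CCN(C2CCN(S(=O)(=O)c3cccc(-c4ccc(F)cc4)c3)CC2)CC1` is not yet measured. It differs from compound 1 in one place: 4-fluorophenyl in place of 2-methoxyphenyl on an aromatic carbon. Among the measured compounds shown here, no measured step of this kind is available, so the expected step from compound 1 to compound 4 in this assay is small, within the scatter or a little toward a higher number. Compound 4 is estimated at 35 nM, with a range from 10 nM to 120 nM, which means a step of a 1.7-fold higher number from compound 1 to compound 4 (0.22 log units; within the scatter).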

Compound 4, half-maximal inhibitory concentration: 12 nM
For compound 4 the middle estimate is 2.9-fold (0.46 log units) above the measured one, and the stated range covers the measured number.
By their numbers in this assay, from the lowest: compounds 4 and 1 (each within the scatter of the next); then compound 3. At a limit, above all of these: compound 2.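

In this assay, 4-fluorophenyl in place of 2-methoxyphenyl on this aromatic carbon gives a 1.8-fold lower number from compound 1 to compound 4 (0.24 log units; within the scatter). This position therefore takes either group, and the hydrogen-bond acceptor that leaves with 2-methoxyphenyl is not required for a value in this range. Nothing measured here bears on a cause for this step. Going by these compounds, the change alters both the substituent and its place on the phenyl ring, so 2-fluorophenyl and 4-methoxyphenyl remain open. Also open, on these data alone, is how an unsubstituted phenyl, a pyridine, or a phenyl carrying an amine or a carboxylic acid would read here.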